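Aryl Swap on the Shared Core: What Compound 4 Should Show

This account rests on a few compounds, and the source may have more. Where it says the series, first, only, none or still open, it means among the compounds named here.

Three compounds share one core and differ only in the aryl group on the nitrogen on an aromatic ring. Compound 1 `COc1cc2ncnc(Nc3ccc(F)c(Cl)c3)c2cc1OCCCCC(=O)Nc1ccc(S(N)(=O)=O)cc1` gives 35600 nM in a functional assay on NCI-H1975 cells (Homo sapiens) for antiproliferative activity, read by MTT assay, with a stated time of 72 h; a higher number here means a weaker inhibitor, a lower number a stronger inhibitor. Compound 2 `COc1cc2ncnc(Nc3ccc(Br)cc3)c2cc1OCCCCC(=O)Nc1ccc(S(N)(=O)=O)cc1` gives 23300 nM in this assay. Compound 3 `COc1ccc(Nc2ncnc3cc(OC)c(OCCCCC(=O)Nc4ccc(S(N)(=O)=O)cc4)cc23)cc1` gives 30200 nM in this assay. On these numbers compound 3 stands second highest of the three, with compound 1 nearest and compound 2 furthest. The gaps are small: a 1.2-fold lower number from compound 1 to compound 3 (0.07 log units; within the scatter) and a 1.3-fold higher number from compound 2 to compound 3 (0.11 log units; within the scatter) both stay within the scatter, as does a 1.5-fold lower number from compound 1 to compound 2 (0.18 log units; within the scatter). Every exchange of this aryl group measured so far has left the number where it was.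

Compound 4 `COc1cc2ncnc(Nc3cccc(Cl)c3F)c2cc1OCCCCC(=O)Nc1ccc(S(N)(=O)=O)cc1` carries the next exchange: 3-chloro-2-fluorophenyl in place of 4-methoxyphenyl on a nitrogen on an aromatic ring. Within the data shown here, the steps that bear on it are the two aryl-for-aryl exchanges at the same place, each within the scatter, and compound 4 differs from compound 3 in the same kind of way. Compound 4 is therefore expected to show a 1.0-fold lower number from compound 3 to compound 4 (0.00 log units; within the scatter), with no movement beyond the scatter in either direction. The estimate for compound 4 in this assay is 30000 nM, with a range from 15000 nM to 60000 nM.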

Compound 4, half-maximal inhibitory concentration: 6930 nM
Estimate against measurement, compound 4: 4.3-fold (0.64 log units) above; measured number below the stated range.
By their numbers in this assay, from the lowest: compound 4; then compounds 2, 3 and 1 (each within the scatter of the next).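

In this assay the aryl group on the nitrogen on an aromatic ring turns out not to be the silent place that the earlier exchanges suggested: with 3-chloro-2-fluorophenyl there, the number drops beyond the scatter against each of the other three aryl groups (a 4.4-fold lower number from compound 3 to compound 4 (0.64 log units; beyond the scatter); a 3.4-fold lower number from compound 2 to compound 4 (0.53 log units; beyond the scatter); a 5.1-fold lower number from compound 1 to compound 4 (0.71 log units; beyond the scatter)). The last of these steps is the most telling, since 3-chloro-4-fluorophenyl and 3-chloro-2-fluorophenyl carry the same two halogens and differ only in where the fluorine stands, so having chlorine and fluorine on this ring does not by itself give the lower number. Nothing in the material shown explains why this one exchange moves the number.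

The compounds shown leave open how much of the step belongs to each halogen, which 3-chlorophenyl and 2-fluorophenyl on the same nitrogen would separate. They also leave open whether 3-chloro-2-fluorophenyl keeps its advantage when the rest of the molecule changes, for instance with a shorter chain or with a carboxylic acid in place of the sulfonamide.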